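Swapping Benzyl for Cyclohexyl on the Amide Nitrogen

The source may hold more compounds than are shown below. What is called first, only, known or untested is meant among the compounds shown, and "the series" means these compounds.

Two compounds share a core in which an amide carries a benzyl group on its nitrogen. Compound 1, `O=C(NCc1ccccc1)c1cc(Oc2ccc(/C=C/c3ccccn3)cc2)ccn1`, gives 18800 nM in a functional assay on A549 cells (Homo sapiens) for antiproliferative activity, read by CCK-8 assay, with a stated time of 48 h; on this read-out higher numbers stand for weaker inhibition and lower numbers for stronger inhibition. Compound 2, `O=C(NCc1ccccc1)c1cc(Oc2ccc(/C=C/c3ccncc3)cc2)ccn1`, gives 17000 nM in this assay. Among the measured compounds shown here, the one measured step, a 1.1-fold lower number from compound 1 to compound 2 (0.04 log units; within the scatter), lies within the scatter, so the two compounds cannot be ranked: compound 2 simply has the lowest of the two numbers, with compound 1 within the scatter of it.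

Compound 3, `O=C(NC1CCCCC1)c1cc(Oc2ccc(/C=C/c3ccncc3)cc2)ccn1`, has not yet been measured in this assay. It differs from compound 2 by cyclohexyl in place of benzyl on an amide-type nitrogen. For the measured compounds named here, no measured step touches the amide nitrogen; the only step recorded, a 1.1-fold lower number from compound 1 to compound 2 (0.04 log units; within the scatter), concerns a different part of the molecule and was itself within the scatter, so it offers no guide to this change. With nothing to lean on, the expected step of no change at the digits printed from compound 2 to compound 3 (within the scatter) is estimated to stay within the scatter, with a wide range to allow for a surprise in either direction. Compound 3 is therefore estimated at 17000 nM in this assay, between 7000 nM and 45000 nM.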

Compound 3, half-maximal inhibitory concentration: 16800 nM
Beside the measured number, compound 3's estimate is 1.0-fold (0.01 log units) above it; low and high end bracket the measured number.
By their numbers in this assay, from the lowest: compounds 3, 2 and 1 (each within the scatter of the next).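

On the amide nitrogen, cyclohexyl in place of benzyl gives a 1.0-fold lower number from compound 2 to compound 3 (0.01 log units; within the scatter) in this assay, so this first change at this position does not separate the two compounds. Compound 3 has a non-aromatic ring at this place where compound 2 has an aromatic one, and their numbers still lie within the scatter of each other, so an aromatic ring on this nitrogen is not required for the activity seen in this pair, though this single pair says nothing about other groups. Nothing available explains why the two rings give such similar numbers.

On these data alone, what a methyl group, a longer alkyl chain, or a chain ending in an amine or a carboxylic acid would do on this nitrogen stays open, so it is unknown whether any group here can shift the number beyond the scatter. Also open is whether cyclohexyl would behave in the same way alongside the pyridin-2-yl group of compound 1, since the compounds shown carry cyclohexyl only with pyridin-4-yl.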